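A few compounds are considered here, and "the series" means these few. Any claim that something is new, unique, unknown or untested is made for them only; others in the source may bear on it.

Of the compounds shown here, three of one shared core have been measured in a functional assay on HeLa cells (Homo sapiens) for cytotoxicity, read by MTT assay, with a stated time of 48 h; on this read-out higher numbers stand for weaker inhibition and lower numbers for stronger inhibition. Compound 1 `Cc1noc2c1N=C(c1ccco1)CC(c1ccccc1)C2C(c1ccccc1)C1c2onc(C)c2N=C(c2ccco2)CC1c1ccccc1` gives 32.7 ug/mL. Compound 2 `Cc1noc2c1N=C(c1ccccc1)CC(c1ccccc1)C2C(c1ccc(Cl)cc1)C1c2onc(C)c2N=C(c2ccccc2)CC1c1ccccc1` gives 55.9 ug/mL, and compound 3 `Cc1ccc(C2CC(c3ccccc3)=Nc3c(C)noc3C2C(c2ccccc2)C2c3onc(C)c3N=C(c3ccccc3)CC2c2ccc(C)cc2)cc1` gives 53.3 ug/mL. On these numbers compound 2 sits at the top of the three, yet its distance to compound 3 and its distance to compound 1 both lie within the usual scatter of this assay, so the three cannot be told apart with confidence.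

Compound 4 `Cc1noc2c1N=C(c1ccccc1)CC(c1ccccc1)C2C(c1ccccc1)C1c2onc(C)c2N=C(c2ccccc2)CC1c1ccccc1` has not yet been measured. It differs from compound 2 in one spot: hydrogen in place of chloro on an aromatic carbon, which, cut one bond further out, reads as 4-chlorophenyl to phenyl. Going by the values given here, no step between any two measured compounds is available that would show what such a change does on this core, so nothing in the data points to a shift in either direction. The expected step from compound 2 to compound 4 is therefore a 1.2-fold lower number from compound 2 to compound 4 (0.09 log units; within the scatter), which is no more than the scatter. Compound 4 is estimated at 45 ug/mL, with a range from 22 ug/mL to 95 ug/mL.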

Compound 4, half-maximal inhibitory concentration: 68.7 ug/mL
Beside the measured number, compound 4's estimate is 1.5-fold (0.18 log units) below it; measured number inside the range.
By their numbers in this assay, from the lowest: compounds 1, 3, 2 and 4 (each within the scatter of the next, the first and the last beyond it).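

Going by these compounds alone, this is the first direct comparison at this position on the shared core: in this assay, replacing chloro with hydrogen on the aromatic ring of the 4-chlorophenyl group gives a 1.2-fold higher number from compound 2 to compound 4 (0.09 log units; within the scatter). On this core, then, losing the chloro at this place, para to a large group, produces no difference that the assay can separate from ordinary variation between repeats. Nothing measured here offers an explanation for this result.

On these data alone, whether a different group at this spot, such as a methoxy group, an amine or a carboxylic acid, would shift the number beyond the scatter remains open. Compound 1 and compound 3 each differ from the other compounds in more than one place, and steps involving them cannot be read.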